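This account rests on a few compounds, and the source may have more. Where it says the series, first, only, none or still open, it means among the compounds named here.

Measured in a functional assay on Jurkat cells (Homo sapiens); a higher number here means a weaker inhibitor, a lower number a stronger inhibitor
- compound 1 `C[C@H](NC(=O)C(=O)NCC1CCCCC1)C(=O)N[C@@H](CC(=O)O)C(=O)COc1c(F)c(F)cc(F)c1F` gives 19 nM
- compound 2 `C[C@H](NC(=O)C(=O)NCc1cccc(Cl)c1Cl)C(=O)N[C@@H](CC(=O)O)C(=O)COc1c(F)c(F)cc(F)c1F` gives 76 nM

Compound 2 at 76 nM is the weaker inhibitor of the two. The change to compound 3 `C[C@H](NC(=O)C(=O)NCc1cc(Cl)ccc1Cl)C(=O)N[C@@H](CC(=O)O)C(=O)COc1c(F)c(F)cc(F)c1F` is 2,5-dichlorophenyl in place of 2,3-dichlorophenyl on a saturated chain carbon bound to an amide-type nitrogen, so the two have the same atoms, joined differently. Among the measured compounds shown here, the only measured step is a 4.0-fold higher number from compound 1 to compound 2 (0.60 log units; beyond the scatter) and it swaps cyclohexyl for 2,3-dichlorophenyl at that place, a modest step beyond the scatter for a different kind of change. For the measured compounds named here, no measured step moves a chlorine, so in this assay no shift beyond the scatter is expected and neither direction is favoured. The expected step is a 1.1-fold lower number from compound 2 to compound 3 (0.04 log units; within the scatter) and it lies within the scatter. For compound 3 the estimated value is 70 nM with an expected range from 30 nM to 170 nM on this reasoning.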

Compound 3, half-maximal inhibitory concentration: 4.3 nM
Compound 3: middle estimate off by 16-fold (1.21 log units), on the high side, outside the stated range (below it).
By their numbers in this assay, from the lowest: compound 3; then compound 1; then compound 2.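

In this assay, the arrangement of the two chlorines on the ring matters at this place on the chain: 2,5-dichlorophenyl in place of 2,3-dichlorophenyl gives an 18-fold lower number from compound 2 to compound 3 (1.25 log units; beyond the scatter), although the two groups have the same atoms. The comparison with cyclohexyl therefore depends on the chlorine pattern, as 2,3-dichlorophenyl gave a higher number than cyclohexyl, whereas 2,5-dichlorophenyl gives a 4.4-fold lower number from compound 1 to compound 3 (0.65 log units; beyond the scatter). Nothing available bears on why the pattern matters so much.

Which of the two chlorines of the 2,5-dichlorophenyl group carries the gain remains open, as no compound with a single chlorine on the ring is shown. Also open, going by these compounds, is whether bromine or methyl in place of those chlorines would keep the number as low as in compound 3.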